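The source may hold more compounds than are shown below. What is called first, only, known or untested is meant among the compounds shown, and "the series" means these compounds.

Compound 1 `COc1cc(-c2cc(/C=C/C(=O)c3ccc(Cl)c(Cl)c3)[nH]n2)cc(OC)c1OC`: 96%
Compound 2 `COc1ccc(-c2cc(/C=C/C(=O)c3ccc(N)cc3)[nH]n2)cc1OC`: 99%
Compound 3 `COc1ccc(-c2cc(/C=C/C(=O)c3cc(OC)c(OC)c(OC)c3)[nH]n2)cc1OC`: 103%

Of the compounds shown here, three have been measured in a functional assay on RXF 393 cells (Homo sapiens) for cytotoxicity, read by sulforhodamine B assay, with a stated time of 48 h, tested at 0.01 uM; on this read-out lower numbers stand for a stronger effect and higher numbers for a weaker effect at the one concentration tested. Compound 1 gives 96%, compound 2 gives 99% and compound 3 gives 103%. The number for compound 1 is the one beneath the other two, yet both gaps fall within the scatter, so the three compounds cannot be told apart on this read-out. Compound 4 `COc1ccc(C(=O)/C=C/c2cc(-c3cc(OC)c(OC)c(OC)c3)n[nH]2)cc1OC` has not yet been measured. It differs from compound 1 in one place: 3,4-dimethoxyphenyl in place of 3,4-dichlorophenyl on a carbonyl carbon. Going by the values given here, no step between measured compounds exists to guide the expectation, and nothing in the three numbers suggests a shift beyond the scatter for compound 4 in this assay. The expected step of a number 3 percentage points higher from compound 1 to compound 4 (within the scatter) is therefore none beyond the scatter. Compound 4 is estimated at 99%, between 88% and 110%.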

Compound 4, a percentage reported as activity, at one concentration (the size of the read-out at that concentration, not a potency): 100%
Estimate against measurement, compound 4: 1 percentage points below; low and high end bracket the measured number.
By their numbers in this assay, from the lowest: compounds 1, 2, 4 and 3 (each within the scatter of the next).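

In this assay, 3,4-dimethoxyphenyl in place of 3,4-dichlorophenyl on a carbonyl carbon gives a number 4 percentage points higher from compound 1 to compound 4 (within the scatter). Going by these compounds alone, this is the first single-place step available here, and it shows that this exchange at this position leaves the read-out unresolved at the one concentration tested. No measurement shown explains why the two compounds read alike.

Still open, as far as these compounds go, is whether a carboxylic acid or a nitrile on the phenyl ring at this position would move the number beyond the scatter. Also open, from the compounds shown here alone, is whether this exchange would remain silent at higher concentrations, where the compounds might show a clearer effect.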